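A few compounds are considered here, and "the series" means these few. Any claim that something is new, unique, unknown or untested is made for them only; others in the source may bear on it.

Measured compounds in a functional assay on B16-F10 cells (Mus musculus) for antiproliferative activity, read by ELISA and MTT assay, with a stated time of 48 h; a higher number here means a weaker inhibitor, a lower number a stronger inhibitor:
- compound 1, `O=C(/C=C/c1ccc(Cl)cc1)NS(=O)(=O)c1ccccc1`, gives 2.2 ug/mL
- compound 2, `Cc1ccc(S(=O)(=O)NC(=O)/C=C/c2ccc(Cl)cc2)cc1`, gives 4.6 ug/mL
- compound 3, `O=C(/C=C/c1ccc(Cl)cc1)NS(=O)(=O)c1ccc(F)cc1`, gives 2 ug/mL

Compound 3 has the lowest number of the three in this assay. Its nearest neighbour is compound 1, a step of a 1.1-fold lower number from compound 1 to compound 3 (0.04 log units; within the scatter) that lies within the scatter, so the two cannot be told apart; its furthest is compound 2, where a 2.3-fold lower number from compound 2 to compound 3 (0.36 log units; beyond the scatter) is a modest step beyond the scatter.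

Compound 4 is `O=C(/C=C/c1ccc(Cl)cc1)NS(=O)(=O)c1ccc(Br)cc1`. It differs from compound 3 in one place: bromo in place of fluoro on an aromatic carbon. The change sits on an aromatic carbon of a six-membered aromatic ring of carbon only, para to a large group.

Among the measured compounds shown here, no measured step swaps fluoro for bromo. For the measured compounds named here, the steps that bear on this spot are a 1.1-fold lower number from compound 1 to compound 3 (0.04 log units; within the scatter), within the scatter, and a 2.3-fold lower number from compound 2 to compound 3 (0.36 log units; beyond the scatter), a modest step. Those show that a hydrogen or a fluoro at this spot give similar numbers, while a methyl gives a modestly higher one. A bromo is expected to fall somewhere in that span, so the step of a 1.3-fold higher number from compound 3 to compound 4 (0.11 log units; within the scatter) is expected to be small, if anything toward a higher number. Compound 4 is therefore estimated at 2.6 ug/mL, with a range from 1.2 ug/mL to 5.5 ug/mL in this assay.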

Compound 4, half-maximal inhibitory concentration: 2.8 ug/mL
For compound 4 the middle estimate is 1.1-fold (0.03 log units) below the measured one; the range from low to high includes it.
By their numbers in this assay, from the lowest: compounds 3, 1, 4 and 2 (each within the scatter of the next, the first and the last beyond it).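

In this assay, bromo in place of fluoro gives a 1.4-fold higher number from compound 3 to compound 4 (0.15 log units; within the scatter) and bromo in place of hydrogen gives a 1.3-fold higher number from compound 1 to compound 4 (0.10 log units; within the scatter) so a bromo at this spot on the ring cannot be told apart from either of those two groups. Bromo in place of methyl gives a 1.6-fold lower number from compound 2 to compound 4 (0.22 log units; within the scatter) which is also within the scatter, even though compound 2 stands beyond the scatter from both compound 1 and compound 3. Compound 4 therefore sits in the gap between those two levels, and it adds a fourth group at this spot without showing whether bromo belongs with hydrogen and fluoro or with methyl.

All four groups shown give numbers close together, so it remains open whether an amine, a carboxylic acid or a longer chain at this spot would move the number much further in either direction. Nothing available here explains why these groups give the numbers they do.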